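A few compounds are considered here, and "the series" means these few. Any claim that something is new, unique, unknown or untested is made for them only; others in the source may bear on it.

Measured compounds:
compound 1, `c1ccc(Oc2ncnc3[nH]ccc23)cc1`, 3200 nM in an assay on HEK293-TREx cells for antagonist activity at transient receptor potential cation channel subfamily A member 1 (Homo sapiens), read by fluorescence and calcium flux, with a stated time of 72 h; on this read-out lower numbers stand for stronger inhibition and higher numbers for weaker inhibition
compound 2, `Fc1cccc(Oc2ncnc3[nH]ccc23)c1F`, 2700 nM in this assay

Compound 2 stands close to compound 1 in this assay: the two numbers lie within the usual scatter of each other, so no order can be read from them. Both compounds share the same core, and differ only in the fluoro groups on the aryl ether ring of compound 2.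

The next compound, compound 3, `Fc1ccccc1Oc1ncnc2[nH]ccc12`, has not yet been measured in this assay. It differs from compound 2 by hydrogen in place of fluoro on an aromatic carbon. Compound 3 thus keeps one of the two fluoro groups of compound 2 and in that sense sits between compound 2 and compound 1, which carries none.

Among the compounds with values here, no step between two measured compounds is available here. As compound 1 and compound 2 agree within the scatter, the loss of a single fluoro group is not expected to move the number in this assay beyond the scatter in either direction. The step from compound 2 to compound 3 is therefore expected to be a 1.1-fold higher number from compound 2 to compound 3 (0.03 log units; within the scatter). For compound 3 in this assay the estimate is 2900 nM, with a range from 1400 nM to 6000 nM.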

Compound 3, half-maximal inhibitory concentration: > 32000 nM
Compound 3: no number, only a limit; the forecaster's own chance of this, stated with the estimate: 5%; middle value at least 11-fold (1.04 log units) from the limit.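

Compound 3 gives no number in this assay, only a limit, > 32000 nM. Hydrogen in place of fluoro on an aromatic carbon gives an at least 11-fold higher number from compound 2 to compound 3 (1.07 log units; beyond the scatter), and fluoro in place of hydrogen on an aromatic carbon gives an at least 10-fold higher number from compound 1 to compound 3 (1.00 log units; beyond the scatter), so the single-fluoro compound stands apart from both its neighbours in the series, a gap that the two earlier compounds, within the scatter of each other, gave no sign of. The fluoro group on the carbon meta to a large group and ortho to a fluoro group therefore counts heavily when the other fluoro group stays on the ring, and the number of fluoro groups alone does not order these three compounds, since compound 1, with none, goes against any such trend.

Going by these compounds, how far compound 3 lies from the other two remains unknown, and the size of both steps stays open-ended: the limit of > 32000 nM in this assay, at which 1 of the 3 values shown sits. Still open is whether chloro, methyl, methoxy or an amine on that same aromatic carbon would behave like the fluoro group of compound 2 or like the hydrogen of compound 3, and the compounds shown give no cause for the gap.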